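This account rests on a few compounds, and the source may have more. Where it says the series, first, only, none or still open, it means among the compounds named here.

Measured compounds:
compound 1 `COc1nc(C)c(Nc2nc(Cl)cn([C@H](CO)C3CC3)c2=O)cc1C` — 88 nM
compound 2 `COc1nc(C)c(Nc2nc(Cl)cn([C@H](COC(C)=O)C3CC3)c2=O)cc1C` — 5.3 nM
compound 3 `COc1nc(C)c(Nc2nc(Cl)cn([C@H](COC(=O)c3ccccn3)C3CC3)c2=O)cc1C` — 67 nM

In an assay on frontal cortex for displacement of a labelled ligand from corticotropin-releasing factor receptor 1 (Rattus norvegicus), with a stated time of 2 h (on this read-out lower numbers stand for stronger inhibition and higher numbers for weaker inhibition), compound 3 gives the second highest of the three numbers. Its nearest neighbour is compound 1, a gap that lies within the scatter; its furthest is compound 2, with a 13-fold higher number from compound 2 to compound 3 (1.10 log units; beyond the scatter) separating them. Compound 4 `COc1nc(C)c(Nc2nc(Cl)cn([C@H](COC(=O)Nc3ccc(Cl)cc3)C3CC3)c2=O)cc1C` is not yet measured and differs from compound 3 in one place: (4-chlorophenyl)amino in place of pyridin-2-yl on a carbonyl carbon.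

Within the data shown here, two measured steps concern the same carbonyl carbon. Replacing the hydrogen of the free hydroxyl with an acetyl gave a 17-fold lower number from compound 1 to compound 2 (1.22 log units; beyond the scatter), a large drop, while the larger (pyridin-2-yl)carbonyl gave only a 1.3-fold lower number from compound 1 to compound 3 (0.12 log units; within the scatter), within the scatter. Among the measured compounds shown here, no measured step covers an amino group on that carbonyl carbon, so the size of the step to compound 4 is uncertain. Since (4-chlorophenyl)amino is, like pyridin-2-yl, a six-membered aromatic group, compound 4 is expected to stay close to compound 3, with a step of about a 1.1-fold lower number from compound 3 to compound 4 (0.05 log units; within the scatter), not clearly beyond the scatter. Compound 4 is therefore estimated at 60 nM, within a range of 15 nM to 250 nM.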

Compound 4, half-maximal inhibitory concentration: 1.6 nM
Compound 4: middle estimate off by 38-fold (1.57 log units), on the high side, outside the stated range (below it).
By their numbers in this assay, from the lowest: compound 4; then compound 2; then compounds 3 and 1 (each within the scatter of the next).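

In this assay, the group on this carbonyl carbon matters far more than the first three compounds could show: (4-chlorophenyl)amino in place of pyridin-2-yl gives a 42-fold lower number from compound 3 to compound 4 (1.62 log units; beyond the scatter), so these two groups, each with a six-membered aromatic ring, do not behave alike here. Against the small methyl of the acetyl group, (4-chlorophenyl)amino gives a 3.3-fold lower number from compound 2 to compound 4 (0.52 log units; beyond the scatter), a modest step but one beyond the scatter, which shows that a large group on this carbon can outdo a small one. Compared with the free hydroxyl, the (4-chlorophenyl)carbamoyl group gives a 55-fold lower number from compound 1 to compound 4 (1.74 log units; beyond the scatter), leaving compound 4 with the lowest number of the four.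

On these data alone, what phenylamino without the chlorine, or methylamino, would give on this carbonyl carbon remains open, so the shares of the ring, the chlorine and the amino hydrogen in this step cannot be separated. Nothing available here explains why the number falls so far.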